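The source may report more compounds than this note shows. Statements on the series, on what has been measured and on what is new or still open speak of the compounds shown alone.

Compound 1 `CCOC(=O)C1=C(NN=C(C(C)=O)C(C)=O)Nc2[nH]nc(C)c2C1c1ccc(N(C)C)cc1`: 8480 nM
Compound 2 `CCOC(=O)C1=C(N/C=N/c2nnc(S(N)(=O)=O)s2)Nc2[nH]nc(C)c2C1c1ccc(N(C)C)cc1`: 38100 nM
Compound 3 `CCOC(=O)C1=C(N/N=C(\C#N)C(N)=O)Nc2[nH]nc(C)c2C1c1ccc(N(C)C)cc1`: not yet measured

Among the compounds with values here, in a functional assay on HepG2 cells (Homo sapiens) for inhibition, read by MTT assay, with a stated time of 48 h (a higher number here means a weaker inhibitor, a lower number a stronger inhibitor), compound 2 gives 38100 nM, the higher of the two numbers so far and so the weaker inhibitor of the pair. Compound 3 keeps the shared core and changes only the group on the amine nitrogen: a group of 7 heavy atoms (3 carbon, 3 nitrogen, 1 oxygen; no ring) in place of a group of 11 heavy atoms (3 carbon, 4 nitrogen, 2 oxygen, 2 sulfur; one five-membered aromatic ring with 3 hetero atoms), on an amine nitrogen. Within the data shown here, the group that leaves is the one that separates compound 2 from compound 1, and the entering group, like the one in compound 1, has no ring.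

Among the measured compounds shown here, the one measured step that bears on this is a 4.5-fold higher number from compound 1 to compound 2 (0.65 log units; beyond the scatter). It is modest but beyond the scatter. Read in reverse, it points to a lower number once the ring-bearing group is gone. The group in compound 3 is not the same as that in compound 1, and a single step is thin support, so the range stays wide and reaches almost back to compound 2.

The expected change in this assay is a 3.5-fold lower number from compound 2 to compound 3 (0.54 log units; beyond the scatter), of similar size to the measured step. Compound 3 is estimated at 11000 nM, with an expected range of 3500 nM to 35000 nM.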

Compound 3, half-maximal inhibitory concentration: 48400 nM
Compound 3: middle estimate off by 4.4-fold (0.64 log units), on the low side; the measured number lies above the stated range.
By their numbers in this assay, from the lowest: compound 1; then compounds 2 and 3 (each within the scatter of the next).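

In this assay, losing the ring is not enough to reach the level of compound 1: the exchange of the five-membered aromatic ring group for the group carrying a nitrile and no ring gives a 1.3-fold higher number from compound 2 to compound 3 (0.10 log units; within the scatter) and so does not separate these two quite different groups at this place. Both groups compared in a 5.7-fold higher number from compound 1 to compound 3 (0.76 log units; beyond the scatter) have no ring, so the presence of a ring does not account for what sets compound 1 apart, and compound 1 remains the strongest inhibitor of the three in this assay, with a clear step to each of the others. Nothing among the data shown offers an explanation for these numbers.

Going by these compounds, what remains open is which part of the group in compound 1 goes with its lower number, since that group differs from the other two in more than one feature at once. A plain primary amine or a short alkyl chain on this amine nitrogen, or a carboxylic acid in place of the amide of compound 3, would show whether the numbers at this place can move further from those of compound 2 and compound 3.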